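Sulfonyl substituent changes in a K-ATP channel inhibitor series

The compounds below may be only part of what the source reports. "The series", "measured", "known", "first", "only" and "open" are said of these compounds alone.

Compound 1 `CC(O)(C(=O)Nc1ccc(S(=O)(=O)c2ccccc2C#N)cc1)C(F)(F)F`: 1100 nM
Compound 2 `CC(O)(C(=O)Nc1ccc(S(=O)(=O)c2cccc(Cl)c2)cc1)C(F)(F)F`: 10000 nM
Compound 3 `CN(c1ccccc1)S(=O)(=O)c1ccc(NC(=O)C(C)(O)C(F)(F)F)cc1`: 2000 nM

In a functional assay (Cavia porcellus) with sulfonylurea receptors; K-ATP channels (Homo sapiens) as the target (a higher number here means a weaker inhibitor, a lower number a stronger inhibitor), compound 3 gives 2000 nM, the second highest of the three numbers; its step to compound 1 lies within the scatter, while compound 2 sits a 5.0-fold lower number from compound 2 to compound 3 (0.70 log units; beyond the scatter) above it. Compound 4 `CC(O)(C(=O)Nc1ccc(S(=O)(=O)c2ccccn2)cc1)C(F)(F)F` differs from compound 3 only at the sulfonyl sulfur: pyridin-2-yl in place of methyl(phenyl)amino on a sulfonyl sulfur. Among the compounds with values here, the steps that bear on this change are the other exchanges at the same sulfur, a 9.1-fold higher number from compound 1 to compound 2 (0.96 log units; beyond the scatter) and a 1.8-fold higher number from compound 1 to compound 3 (0.26 log units; within the scatter) and a 5.0-fold lower number from compound 2 to compound 3 (0.70 log units; beyond the scatter), which show that this position can move the number modestly or not at all. An aromatic ring directly on the sulfur is expected to resemble compound 1 more than compound 2, so the estimated step is a 1.3-fold lower number from compound 3 to compound 4 (0.12 log units; within the scatter), giving compound 4 an expected 1500 nM with a range of 400 nM to 6000 nM.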

Compound 4, half-maximal inhibitory concentration: 600 nM
The estimate for compound 4 lay 2.5-fold (0.40 log units) above the measured number, and the stated range covers the measured number.
By their numbers in this assay, from the lowest: compounds 4, 1 and 3 (each within the scatter of the next, the first and the last beyond it); then compound 2.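

In this assay the pyridin-2-yl group gives a 3.3-fold lower number from compound 3 to compound 4 (0.52 log units; beyond the scatter) and also a 17-fold lower number from compound 2 to compound 4 (1.22 log units; beyond the scatter), the largest step yet seen at this sulfonyl sulfur, so this position can move the number by a large amount as well as a modest one. Against the 2-cyanophenyl group there is a 1.8-fold lower number from compound 1 to compound 4 (0.26 log units; within the scatter), which leaves compound 4 and compound 1 indistinguishable.

Going by these compounds, it remains open how an unsubstituted phenyl or a pyridin-3-yl on the sulfonyl sulfur would compare, and whether an amine on the ring would shift the number. No measurement available here accounts for these differences.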